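Swapping an aromatic amide for a cyclobutyl amide

This account rests on a few compounds, and the source may have more. Where it says the series, first, only, none or still open, it means among the compounds named here.

Measured compounds:
compound 1, `Cc1cccc(Cn2c(CN3CCN(C(=O)c4ccc(C#N)cc4)CC3)nc3ccccc32)c1`, gives 20.8%
compound 2, `CC(C)Cn1c(CN2CCN(C(=O)C3CC3)CC2)nc2ccccc21`, gives 13.1%

Both were tested in an assay on isolated protein for inhibition of aldehyde dehydrogenase 1A1 (Homo sapiens), read by spectrophotometry, tested at 10 uM; a higher number here means more inhibition at the concentration tested (going by the name of the read-out), a lower number less inhibition. Compound 1 has the highest of the two numbers recorded, but its nearest neighbour, compound 2, sits only within the scatter of it, so no order can be read between them. Compound 3, `Cc1cccc(Cn2c(CN3CCN(C(=O)C4CCC4)CC3)nc3ccccc32)c1`, has not yet been measured. It differs from compound 1 in one place: cyclobutyl in place of 4-cyanophenyl on a carbonyl carbon. Among the measured compounds shown here, no pair of measured compounds shows exactly this change, so its size is not known from the data. Since compound 2, which also carries a small carbon ring on the carbonyl, gives 13.1%, a modest drop or no change beyond the scatter is expected. The step from compound 1 to compound 3 is estimated at a number 5.8 percentage points lower from compound 1 to compound 3 (within the scatter). For compound 3 the expected value in this assay is 15%, with a range from 5% to 28%.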

Compound 3, a percentage reported as inhibition, at one concentration (the size of the read-out at that concentration, not a potency): 69.1%
The estimate for compound 3 lay 54.1 percentage points below the measured number; the whole stated range lies below it.
By their numbers in this assay, from the lowest: compounds 2 and 1 (each within the scatter of the next); then compound 3.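

With the rest of compound 1 unchanged, placing cyclobutyl instead of 4-cyanophenyl on the carbonyl carbon in this assay gives a number 48.3 percentage points higher from compound 1 to compound 3 (beyond the scatter) and shows that this single position can strongly shift inhibition of the enzyme. Compound 1 and compound 2 could not show this, as they differ in more than one place and their values lie within the scatter of each other. No supporting measurement explains the size of this change.

The compounds shown do not separate what the cyclobutyl brings from what the departing 4-cyanophenyl took away. A plain phenyl or a cyclohexyl on the same carbonyl would help to tell whether the nitrile, the aromatic ring or the size of the carbon ring governs the result.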